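Lactone to Fluorinated Lactam: Estimating Compound 4

A few compounds are considered here, and "the series" means these few. Any claim that something is new, unique, unknown or untested is made for them only; others in the source may bear on it.

Measured compounds:
- compound 1 `O=C1OCc2cc(N(Cc3ccc(C4CCCCC4)cn3)C(=O)[C@H]3CCN3S(=O)(=O)c3c(F)c(F)c(F)c(F)c3F)ccc21`: 900 nM
- compound 2 `O=C(NO)c1ccc(N(Cc2ccc(C3CCCC3)cn2)C(=O)[C@H]2CCN2S(=O)(=O)c2c(F)c(F)c(F)c(F)c2F)c(F)c1`: "not determined" (no result reported)
- compound 3 `O=C(NO)c1ccc(N(Cc2cnc(C3CCCCC3)cn2)C(=O)[C@H]2CCN2S(=O)(=O)c2c(F)c(F)c(F)c(F)c2F)cc1O`: 5200 nM

In a functional assay on MDA-MB-231 cells (Homo sapiens) for antiproliferative activity, with a stated time of 72 h (on this read-out lower numbers stand for an effect already at smaller amounts and higher numbers for an effect only at larger amounts of compound), compound 1 gives 900 nM, the lowest of the two numbers available. Compound 3 gives 5200 nM in this assay, a gap to compound 1 that is beyond the usual scatter; for compound 2 this assay reports "not determined" (no result reported), so no number is available for it. Going by the values given here, as compound 3 differs from compound 1 in more than one place, no single step between measured compounds can be drawn from these data.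

Compound 4 `O=C1NCc2cc(N(Cc3ccc(C4CCCCC4)cn3)C(=O)[C@H]3CCN3S(=O)(=O)c3c(F)c(F)c(F)c(F)c3F)c(F)cc21` differs from compound 1 by a group of 11 heavy atoms (8 carbon, 1 nitrogen, 1 oxygen, 1 fluorine; one five-membered non-aromatic ring with 1 hetero atom, one six-membered aromatic ring of carbon only) in place of a group of 10 heavy atoms (8 carbon, 2 oxygen; one five-membered non-aromatic ring with 1 hetero atom, one six-membered aromatic ring of carbon only), on an amide-type nitrogen. The rest of the shared core is unchanged. Among the compounds with values here, with no measured step of this kind to rest on, the author expects the step from compound 1 to compound 4 in this assay to be small, in no clear direction and likely within the scatter, no change at the digits printed from compound 1 to compound 4 (within the scatter). Compound 4 is therefore estimated at 900 nM, with a range from 300 nM to 2700 nM.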

Compound 4, half-maximal effective concentration: 2000 nM
For compound 4 the middle estimate is 2.2-fold (0.35 log units) below the measured one; the measured number falls inside the stated range.
By their numbers in this assay, from the lowest: compound 1; then compound 4; then compound 3.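

In this assay, going by these compounds alone, the exchange on the amide-type nitrogen gives a 2.2-fold higher number from compound 1 to compound 4 (0.35 log units; beyond the scatter) and is the only step between compounds differing in one place here, so it gives this position its first measured size of change. The step is modest, and activity persists when the group of 10 heavy atoms with 0 hydrogen-bond donors and 2 hydrogen-bond acceptors gives way to the group of 11 heavy atoms with 1 hydrogen-bond donor and 1 hydrogen-bond acceptor. Nothing shown gives a reason for this step.

The entering group differs from the leaving one both by a nitrogen in place of an oxygen and by an added fluorine, and the compounds shown do not separate these two changes. Going by these compounds, how an amine or a carboxylic acid in place of this group would read out also remains open.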